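Ester for amide on the side-chain carbonyl

The compounds below may be only part of what the source reports. "The series", "measured", "known", "first", "only" and "open" are said of these compounds alone.

Two analogues of a shared core have been measured in a functional assay on SK-MEL-5 cells (Homo sapiens) for antiproliferative activity; on this read-out higher numbers stand for weaker inhibition of growth and lower numbers for stronger inhibition of growth. Compound 1 `CCOC(=O)C[C@H]1[C@@H](O[Si](C)(C)C(C)(C)C)[C@H](n2cnc3c(NC(=O)Nc4ccccc4)ncnc32)O[C@@H]1COC(=O)NC` gives 5.7 nM in this assay. Compound 2 `CNC(=O)NC[C@H]1O[C@@H](n2cnc3c(NC(=O)Nc4ccccc4)ncnc32)[C@H](O[Si](C)(C)C(C)(C)C)[C@@H]1CC(=O)N(C)OC` gives 5.81 nM in this assay; of the two numbers it sits together with compound 1, the gap being within the scatter, so nothing separates them.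

Compound 3 `CCOC(=O)C[C@H]1[C@@H](O[Si](C)(C)C(C)(C)C)[C@H](n2cnc3c(NC(=O)Nc4ccccc4)ncnc32)O[C@@H]1CNC(=O)NC` remains to be measured. Relative to compound 2 it differs in one place: ethoxy in place of methoxy(methyl)amino on a carbonyl carbon. The rest of compound 2 is kept unchanged. Within the data shown here, no measured pair shows this change on its own; compound 1 and compound 2 differ in more than one place, and their values in this assay fall together. Because compound 2 gives 5.81 nM and compound 1 gives 5.7 nM, the expected step is a 1.1-fold lower number from compound 2 to compound 3 (0.02 log units; within the scatter), none beyond the scatter in either direction. Compound 3 is estimated at 5.5 nM, with a range from 2.5 nM to 13 nM.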

Compound 3, concentration for 50% growth inhibition: 4.34 nM
Compound 3: middle estimate off by 1.3-fold (0.10 log units), on the high side, within the range that was stated.
By their numbers in this assay, from the lowest: compounds 3, 1 and 2 (each within the scatter of the next).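

On a carbonyl carbon whose other neighbour is a saturated chain carbon, ethoxy in place of methoxy(methyl)amino gives a 1.3-fold lower number from compound 2 to compound 3 (0.13 log units; within the scatter) in this assay; this change can now be read on its own, and it stays within the scatter. On a saturated chain carbon bound to a saturated ring carbon, (methylcarbamoyl)amino in place of (methylcarbamoyl)oxy gives a 1.3-fold lower number from compound 1 to compound 3 (0.12 log units; within the scatter), also within the scatter, so neither single change separates its pair on this read-out. Nothing at hand bears on why these values stay together.

It remains open whether a carboxylic acid or a longer alkoxy chain on the same carbonyl carbon would stay within the scatter of these compounds. Going by these compounds, it is equally open whether a free amine on the saturated chain carbon, in place of (methylcarbamoyl)amino, would do so.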